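The source may report more compounds than this note shows. Statements on the series, on what has been measured and on what is new or still open speak of the compounds shown alone.

Among the measured compounds shown here, compound 3 `CCOC(=O)c1cc(-c2ccc(OC(=O)NC3CCCCC3)cc2)n(CC)n1` stands at the highest of the three numbers so far: in an assay on isolated protein for inhibition of Fatty-acid amide hydrolase 1 (Homo sapiens), read by fluorescence, with a stated time of 30 min (a lower number here means a stronger inhibitor, a higher number a weaker inhibitor), compound 3 gives 214 nM. For the measured compounds named here, compound 1 `CCOC(=O)c1cc(-c2cccc(OC(=O)NC3CCCCC3)c2)n(-c2ccc(OC)cc2)n1` gives 103 nM in this assay, and compound 2 `CCOC(=O)c1cc(-c2cccc(OC(=O)NC3CCCCC3)c2)n(-c2ccc(C)cc2)n1` gives 29 nM; the one step between measured compounds that differ in a single place is a 3.6-fold lower number from compound 1 to compound 2 (0.55 log units; beyond the scatter). Compound 4 `CCOC(=O)c1cc(-c2ccc(OC(=O)NC3CCCCC3)cc2)n(-c2ccccc2)n1` is reached from compound 3 by one change: phenyl in place of ethyl on an aromatic nitrogen. Going by the values given here, no measured step covers this change directly; the step from compound 1 to compound 2 alters a group on a phenyl already attached to the ring nitrogen, not the ethyl itself. Compounds 1 and 2 both carry a substituted phenyl on that nitrogen and both show lower numbers than compound 3, yet they also differ from compound 3 elsewhere in the molecule, so they give only a hint. The step from compound 3 to compound 4 is therefore expected to be a modest fall in this assay, a 3.1-fold lower number from compound 3 to compound 4 (0.49 log units; beyond the scatter). Compound 4 is estimated at 70 nM in this assay, with a range from 20 nM to 250 nM.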

Compound 4, half-maximal inhibitory concentration: 268 nM
Beside the measured number, compound 4's estimate is 3.8-fold (0.58 log units) below it; measured number above the stated range.
By their numbers in this assay, from the lowest: compound 2; then compound 1; then compounds 3 and 4 (each within the scatter of the next).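

In this assay, phenyl in place of ethyl on the aromatic nitrogen gives a 1.3-fold higher number from compound 3 to compound 4 (0.10 log units; within the scatter), so with the rest of compound 3 unchanged, this position accepts a six-membered aromatic ring of carbon only in place of the two-carbon ethyl without a shift beyond the scatter. Among the compounds shown here, an unsubstituted phenyl at this position therefore brings no lower number by itself in this pair, which the earlier compounds, differing from compound 3 in more than one place, could not show. The compounds shown offer no evidence that explains this flat step.

Open, on these data alone, is whether a methyl on this phenyl would lower the number in compound 4 as it does in a 3.6-fold lower number from compound 1 to compound 2 (0.55 log units; beyond the scatter). Also open, as far as these compounds go, is how this position responds to a benzyl group, a longer alkyl chain or a chain ending in an amine.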